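A Heavier Sulfonyl Aryl Group and Its Expected Cost

The source may hold more compounds than are shown below. What is called first, only, known or untested is meant among the compounds shown, and "the series" means these compounds.

Of the compounds shown here, three of a shared core have been tested in a functional assay on MDA-MB-231 cells (Homo sapiens) for antiproliferative activity, read by MTT assay; on this read-out lower numbers stand for stronger inhibition and higher numbers for weaker inhibition. Compound 1 `Cc1cc(Nc2ccc(F)cc2)nc(Nc2ccc(NS(=O)(=O)c3ccc(C(F)(F)F)cc3)cc2)n1` gives 17500 nM. Compound 2 `COc1cc(C)cc(Cl)c1S(=O)(=O)Nc1ccc(Nc2nc(C)cc(Nc3ccc(F)cc3)n2)cc1` reaches only the limit of the assay, > 50000 nM, and no number. Compound 3 `COc1ccc(Nc2cc(C)nc(Nc3ccc(NS(=O)(=O)c4ccccc4Cl)cc3)n2)cc1` gives 15300 nM, the lowest of the two numbers, though its gap to compound 1 lies within the scatter.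

Compound 4 `COc1ccc(Nc2cc(C)nc(Nc3ccc(NS(=O)(=O)c4c(Cl)cc(C)cc4OC)cc3)n2)cc1` has not been measured. It differs from compound 3 in one place: 2-chloro-6-methoxy-4-methylphenyl in place of 2-chlorophenyl on a sulfonyl sulfur. Among the compounds with values here, one measured step bears directly on this change, the one from compound 1 to compound 2, where the same group entered on the sulfonyl sulfur and the number rose: an at least 2.8-fold higher number from compound 1 to compound 2 (0.45 log units; beyond the scatter). Within the data shown here, that step is the only guide, and it points to weaker inhibition for compound 4, likely to the extent of the limit, as in the limit of > 50000 nM in this assay, at which 1 of the 3 values shown sits.

Compound 4 is therefore expected to give about 45000 nM in this assay, within a range of 22000 nM to 110000 nM. The expected step from compound 3 to compound 4 is a 2.9-fold higher number from compound 3 to compound 4 (0.47 log units; beyond the scatter).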

Compound 4, half-maximal inhibitory concentration: > 50000 nM
Compound 4: only a limit was reported (the forecaster's own chance of this, stated with the estimate: 55%); middle value at least 1.1-fold (0.04 log units) from the limit.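

The 2-chloro-6-methoxy-4-methylphenyl group on a sulfonyl sulfur now weakens inhibition in a second compound pair: in this assay, replacing 2-chlorophenyl gives an at least 3.2-fold higher number from compound 3 to compound 4 (0.51 log units; beyond the scatter). Within the data shown here, the loss therefore holds with a different group leaving the sulfonyl sulfur, and with methoxy in place of fluoro on an aromatic carbon, so it no longer rests on the single step seen before. Compound 4 gives a limit and not a number: the limit of > 50000 nM in this assay, at which 2 of the 4 values shown sit.

From the compounds shown here alone, the step between compound 2 and compound 4 cannot be read, as both values are limits, so how far each compound lies past the limit remains unknown. Also open, going by these compounds, is which part of the entering group carries the loss, and whether an amine in place of its methoxy would return a measurable number.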